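Lengthening the Chain from Compound 3 to Compound 4

A few compounds are considered here, and "the series" means these few. Any claim that something is new, unique, unknown or untested is made for them only; others in the source may bear on it.

Measured so far in a functional assay, read by spectrophotometry, with a stated time of 6 min; on this read-out lower numbers stand for stronger inhibition and higher numbers for weaker inhibition:
Compound 1 `CCCCCCCCCCCCCCOc1cc(OC)c(Br)cc1C(C)=O` gives 8700000 nM
Compound 2 `CCCCCCOc1cc(OC)ccc1C(C)=O` gives 42100000 nM
Compound 3 `CCCCCCCCCCCCOc1cc(OC)ccc1C(C)=O` gives 40700000 nM

Compound 3 stands within the scatter of compound 2, while compound 1 shows a lower number than compound 3, beyond the scatter. The change leading to compound 4 `CCCCCCCCCCCCCCOc1cc(OC)ccc1C(C)=O` is ethyl in place of hydrogen on a saturated chain carbon, ten or more bonds along the chain from an oxygen on an aromatic ring and nothing else in the structure differs. Among the compounds with values here, the one measured step that bears on it is a 1.0-fold lower number from compound 2 to compound 3 (0.01 log units; within the scatter) and it placed hexyl on a saturated chain carbon without leaving the scatter. In this assay the expected step is a 1.1-fold lower number from compound 3 to compound 4 (0.05 log units; within the scatter) and none beyond the scatter is expected. For compound 4 the estimated value is 36000000 nM with an expected range from 15000000 nM to 70000000 nM in this read-out.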

Compound 4, half-maximal inhibitory concentration: 38000000 nM
Compound 4: middle estimate off by 1.1-fold (0.02 log units), on the low side; measured number inside the range.
By their numbers in this assay, from the lowest: compound 1; then compounds 4, 3 and 2 (each within the scatter of the next).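

In this assay, ethyl in place of hydrogen on the chain gives a 1.1-fold lower number from compound 3 to compound 4 (0.03 log units; within the scatter) and the octyl change gives a 1.1-fold lower number from compound 2 to compound 4 (0.04 log units; within the scatter) so the number stays within the scatter across compound 2, compound 3 and compound 4. Within the data shown here, with the chain held the same, hydrogen in place of bromo on an aromatic carbon gives a 4.4-fold higher number from compound 1 to compound 4 (0.64 log units; beyond the scatter) and this is the only new step beyond the scatter. No evidence accounts for either result. The compounds shown leave open whether chloro in place of bromo, or a carboxylic acid on the chain, would move the number.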